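A Sulfonyl Aryl Exchange Examined for Clearance

The source may hold more compounds than are shown below. What is called first, only, known or untested is meant among the compounds shown, and "the series" means these compounds.

Of the compounds shown here, three have been measured in an ADME assay on microsomes from liver (Homo sapiens) for metabolic stability, tested at 2.5 uM; a higher number here means faster removal of the compound, a lower number slower removal. Compound 1 `O=S(=O)(c1ccc(F)c(Cl)c1)c1cnc2c(F)cccc2c1-c1cccc(Cl)c1` gives 0.18 mL/min. Compound 2 `COc1cccc(-c2c(S(=O)(=O)c3ccc(C)c(F)c3)cnc3c(F)cccc23)c1` gives 4.02 mL/min, and compound 3 `COc1ccc(-c2c(S(=O)(=O)c3ccc(C)c(F)c3)cnc3c(F)cccc23)cc1` gives 3.27 mL/min; among the three numbers compound 3 lies close to compound 2 and far above compound 1. Within the data shown here, the only single-place step, a 1.2-fold lower number from compound 2 to compound 3 (0.09 log units; within the scatter), concerns the aryl on the shared core, not the sulfonyl group. Compound 4 `COc1ccc(-c2c(S(=O)(=O)c3ccc(OC)cc3)cnc3c(F)cccc23)cc1` differs from compound 3 by 4-methoxyphenyl in place of 3-fluoro-4-methylphenyl on a sulfonyl sulfur. Among the measured compounds shown here, no measured step touches this position, so the expectation rests on compound 3 alone. Compound 4 is therefore expected to give about 4.5 mL/min, between 2 mL/min and 10 mL/min. The expected step is a 1.4-fold higher number from compound 3 to compound 4 (0.14 log units; within the scatter), which may well stay within the scatter.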

Compound 4, intrinsic clearance in a liver preparation (reported as CLH), per the amount of preparation that the assay uses: 2.12 mL/min
Compound 4: middle estimate off by 2.1-fold (0.33 log units), on the high side; the measured number falls inside the stated range.
By their numbers in this assay, from the lowest: compound 1; then compounds 4, 3 and 2 (each within the scatter of the next).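

Among these compounds, at the sulfonyl sulfur, the earlier compounds offered no step, and this exchange gives a 1.5-fold lower number from compound 3 to compound 4 (0.19 log units; within the scatter) in this assay. Replacing 3-fluoro-4-methylphenyl with 4-methoxyphenyl therefore leaves compound 3 and compound 4 within the scatter of each other, so this one change at this position gives no measurable separation. Nothing available offers an explanation for this result. The compounds shown leave open how an amine or a carboxylic acid on the aryl at the sulfonyl sulfur would read in this assay. They also do not separate the several places in which compound 1 differs from the others.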